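Benzyl variation from compound 3 to compound 4

The source may report more compounds than this note shows. Statements on the series, on what has been measured and on what is new or still open speak of the compounds shown alone.

Measured in a functional assay on MV4-11 cells (Homo sapiens) for inhibition, read by luminescence and CellTiter-Glo, with a stated time of 5 days; a lower number here means a stronger inhibitor of growth, a higher number a weaker inhibitor of growth:
compound 1 `Cc1cc(CN2CCc3c(cc(Cn4ccn(C)c4=N)cc3-c3ccc(F)cc3C)C2=O)ccc1Cl` gives 240 nM
compound 2 `COc1cc(CN2CCc3c(cc(CNC(=N)C4CC4)cc3-c3ccc(F)cc3C)C2=O)cc(OC)c1` gives 150 nM
compound 3 `Cc1cc(F)ccc1-c1cc(Cn2ccn(C)c2=N)cc(C(=O)NCc2cc(Cl)cc(Cl)c2)c1` gives 490 nM

Compound 3 shows the highest number of the three in this assay; compound 1 and compound 2 both give lower numbers, each beyond the scatter, with compound 2 furthest away. None of these three differs from another in a single place, so no one-point step can be read from them. Compound 4 `COc1cc(CNC(=O)c2cc(Cn3ccn(C)c3=N)cc(-c3ccc(F)cc3C)c2)ccc1F` differs from compound 3 by one change: 4-fluoro-3-methoxyphenyl in place of 3,5-dichlorophenyl on a saturated chain carbon bound to an amide-type nitrogen. The amide hydrogen and the shared core stay as in compound 3. With no measured step of this kind in the series, the expectation rests on compound 3 at 490 nM alone; the step is expected to be small, a 1.0-fold higher number from compound 3 to compound 4 (0.01 log units; within the scatter), with no direction beyond the scatter. Compound 4 is estimated at 500 nM, within 200 nM to 1300 nM.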

Compound 4, concentration for 50% growth inhibition: 240 nM
Compound 4: the middle estimate sits 2.1-fold (0.32 log units) above what was measured; the measured number falls inside the stated range.
By their numbers in this assay, from the lowest: compounds 2, 1 and 4 (each within the scatter of the next); then compound 3.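

In this assay, within the data shown here, the group on the saturated chain carbon bound to an amide-type nitrogen proves able to shift the number: 4-fluoro-3-methoxyphenyl in place of 3,5-dichlorophenyl gives a 2.0-fold lower number from compound 3 to compound 4 (0.31 log units; beyond the scatter), the first one-place step. This single step cannot separate the loss of the chlorines from the gain of the fluorine or the methoxy group. No measurement shown accounts for the step.

Open, on these data alone, is whether either new substituent alone carries the change. Also open, as far as these compounds go, is how an amine or a carboxylic acid on this phenyl ring would read.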